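The compounds below may be only part of what the source reports. "The series", "measured", "known", "first", "only" and "open" are said of these compounds alone.

Three chalcone-type compounds built on one shared core have been examined in a functional assay on MDA-MB-231 cells (Homo sapiens) for antiproliferative activity, read by MTT assay, with a stated time of 24 h; on this read-out higher numbers stand for weaker inhibition and lower numbers for stronger inhibition. Compound 1, `COc1ccc(C(=O)/C=C/c2cc(-c3cc(OC)c(OC)c(OC)c3)n3nc(-c4ccccc4)cc3n2)cc1OC`, gives 18300 nM in this assay. Compound 2, `COc1ccc(C(=O)/C=C/c2cc(-c3ccc(OC)c(OC)c3)n3nc(-c4ccccc4)cc3n2)cc1`, gives 13900 nM. Compound 3, `COc1ccc(/C=C/C(=O)c2cc(-c3cc(OC)c(OC)c(OC)c3)n3nc(-c4ccccc4)cc3n2)cc1OC`, gives 14200 nM, the second highest of the three numbers; its nearest neighbour is compound 2, whose number lies within the scatter of it, and even the furthest number, that of compound 1, is also within the scatter. On these figures, then, the three compounds cannot be told apart.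

The account now turns to compound 4, `COc1ccc(/C=C/C(=O)c2cc(-c3cc(OC)c(OC)c(OC)c3)n3nc(-c4ccccc4)cc3n2)cc1`, which has not yet been measured. It differs from compound 3 in one place: hydrogen in place of methoxy on an aromatic carbon. Put more broadly, the 3,4-dimethoxyphenyl becomes a 4-methoxyphenyl, the hydrogen entering on an aromatic carbon ortho to a methoxy group and meta to a large group.

Going by the values given here, no pair of the measured compounds differs in this single place, so no measured step shows what removing one methoxy does here. Since all three measured numbers sit within the scatter of one another, the expectation is a step from compound 3 to compound 4 of a 1.0-fold higher number from compound 3 to compound 4 (0.01 log units; within the scatter), that is, none beyond the scatter. Compound 4 is therefore estimated at 14500 nM, within a range of 7000 nM to 30000 nM.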

Compound 4, half-maximal inhibitory concentration: 16500 nM
Beside the measured number, compound 4's estimate is 1.1-fold (0.06 log units) below it; the measured number falls inside the stated range.
By their numbers in this assay, from the lowest: compounds 2, 3, 4 and 1 (each within the scatter of the next).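

In this assay, going by these compounds alone, the removal of one methoxy group, which turns the 3,4-dimethoxyphenyl into a 4-methoxyphenyl, gives a 1.2-fold higher number from compound 3 to compound 4 (0.07 log units; within the scatter) and is the first single-place step on record for this aromatic carbon, ortho to a methoxy group and meta to a large group. On this pair, hydrogen and methoxy at this position cannot be told apart, so the loss of these two heavy atoms and one hydrogen-bond acceptor has no effect beyond the scatter on the read-out, a finding that applies to this one pair alone. No measurement on hand offers an explanation for this result.

Still open, going by these compounds, is whether another group on this same aromatic carbon, such as a hydroxyl, a fluorine, an amine or a longer ether chain, would stand apart from hydrogen and methoxy in this assay on the shared core. Also open, on these data alone, is whether the same exchange of methoxy for hydrogen, made on compound 1, would likewise stay within the scatter.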